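Replacing a methylpiperazine with piperidine on the saturated ring

The source may report more compounds than this note shows. Statements on the series, on what has been measured and on what is new or still open speak of the compounds shown alone.

Of the compounds shown here, three have been measured in an assay on isolated protein for antagonist activity at Substance-P receptor (Homo sapiens); a higher number here means a weaker inhibitor, a lower number a stronger inhibitor. Compound 1 `CN(C)C1CCC(COCc2cc(C(F)(F)F)cc(C(F)(F)F)c2)(c2ccccc2)C1` gives 8 nM, and compound 2 `FC(F)(F)c1cc(COCC2(c3ccccc3)CCC(N3CCCC3)C2)cc(C(F)(F)F)c1` gives 14 nM; the change between them, a 1.8-fold higher number from compound 1 to compound 2 (0.24 log units; within the scatter), lies within the scatter. Compound 3 `CN1CCN(C2CCC(COCc3cc(C(F)(F)F)cc(C(F)(F)F)c3)(c3ccccc3)CC2)CC1` gives 120 nM, the highest of the three numbers, beyond the scatter from both compound 2 and compound 1.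

Compound 4 `FC(F)(F)c1cc(COCC2(c3ccccc3)CCC(N3CCCCC3)CC2)cc(C(F)(F)F)c1` is the next step: piperidin-1-yl in place of 4-methylpiperazin-1-yl on a saturated ring carbon. Among the compounds with values here, no measured step matches this change exactly. Within the data shown here, the one amine-to-amine step available, from compound 1 to compound 2, swapped one small amine for another on a different core and stayed within the scatter. The gap between compound 3 and the two simpler amines of compound 1 and compound 2 suggests that the 4-methylpiperazin-1-yl group goes with a weaker result than a plain cyclic amine, but the cores also differ, so this remains uncertain. In this assay compound 4 is therefore expected to move toward the lower numbers of compounds 1 and 2, with a step of a 4.8-fold lower number from compound 3 to compound 4 (0.68 log units; beyond the scatter). The estimate for compound 4 is 25 nM, with a likely range from 8 nM to 80 nM.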

Compound 4, half-maximal inhibitory concentration: 93 nM
Compound 4: the middle estimate sits 3.7-fold (0.57 log units) below what was measured; measured number above the stated range.
By their numbers in this assay, from the lowest: compounds 1 and 2 (each within the scatter of the next); then compounds 4 and 3 (each within the scatter of the next).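

On a saturated ring carbon of this six-membered ring of carbon only, piperidin-1-yl and 4-methylpiperazin-1-yl cannot be told apart in this assay (a 1.3-fold lower number from compound 3 to compound 4 (0.11 log units; within the scatter)). Removing the second ring nitrogen and its methyl group therefore leaves the reading unchanged within the scatter, so the 4-methylpiperazin-1-yl group alone cannot account for the gap that compound 3 showed from the two lowest numbers. Nothing measured on these compounds explains why the two amines read alike.

Going by these compounds, compounds 1 and 2 differ from compounds 3 and 4 in the core as well as the amine, so it remains open whether the core of compound 1, rather than the choice of amine, goes with their lower numbers; dimethylamino or pyrrolidin-1-yl on the core of compound 4 would separate the two. On these data alone, it is also open whether a morpholin-4-yl ring, or a primary amine, at this ring carbon would read like compound 3 and compound 4 or move away from them.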